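The compounds below may be only part of what the source reports. "The series", "measured", "known", "first", "only" and "open" are said of these compounds alone.

Compound 1 `Cc1c(C(=O)N=C(N)N)ccc(Cl)c1S(C)(=O)=O` gives 1300 nM in a functional assay for inhibition of sodium/hydrogen exchanger (Oryctolagus cuniculus); on this read-out higher numbers stand for weaker inhibition and lower numbers for stronger inhibition.
Compound 2 `Cc1cc(C2CCCCC2)c(S(C)(=O)=O)cc1C(=O)N=C(N)N` gives 22 nM in this assay.
Compound 3 `Cc1cc(-c2cc(C(F)(F)F)cc(C(F)(F)F)c2)c(S(C)(=O)=O)cc1C(=O)N=C(N)N` gives 2800 nM in this assay.

Among these three, compound 2 has the lowest number, and so the strongest inhibition: the number for compound 1 stands clearly higher, beyond the usual scatter, and the number for compound 3 stands higher still, also beyond the scatter. Compound 4 `Cc1cc(SC(C)(C)C)c(S(C)(=O)=O)cc1C(=O)N=C(N)N` has not yet been measured in this assay. It differs from compound 2 in one place: (tert-butyl)sulfanyl in place of cyclohexyl on an aromatic carbon. The new group has five heavy atoms against the six of the cyclohexyl it replaces, and it has no ring, sitting ortho to a methylsulfonyl group as before. No measured pair of these compounds follows such a step, so there is no measured change to lean on. Given the position of compound 2 at 22 nM, the expectation for compound 4 is a modest rise in the number, a step of a 2.7-fold higher number from compound 2 to compound 4 (0.44 log units; beyond the scatter), quite possibly still within the scatter. Compound 4 is therefore estimated at 60 nM, with a range from 15 nM to 250 nM.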

Compound 4, half-maximal inhibitory concentration: 22 nM
Compound 4: middle estimate off by 2.7-fold (0.44 log units), on the high side; low and high end bracket the measured number.
By their numbers in this assay, from the lowest: compounds 2 and 4 (each within the scatter of the next); then compound 1; then compound 3.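

In this assay, putting (tert-butyl)sulfanyl in place of cyclohexyl gives no change at the digits printed from compound 2 to compound 4 (within the scatter). Among the compounds shown here, this is the first direct comparison at this position, on an aromatic carbon ortho to a methylsulfonyl group, and it shows that the number holds when a six-membered carbon ring gives way to a group with no ring and a sulfur atom. Nothing measured here explains why these two groups give matching numbers.

As far as these compounds go, it remains open whether a plain tert-butyl group, without the sulfur, would give a matching number at this position. From the compounds shown here alone, the same question stands for other replacements, such as a tert-butylsulfonyl group, a methoxy group or an amine, so how widely this position accepts change is still unknown.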